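This account rests on a few compounds, and the source may have more. Where it says the series, first, only, none or still open, it means among the compounds named here.

Measured so far in a functional assay on HEK293 cells for agonist activity at prostaglandin E2 receptor EP2 subtype (Rattus norvegicus), read by cAMP accumulation; a lower number here means that less compound is needed, a higher number that more compound is needed for the effect:
Compound 1, `CCCCCC(=O)c1ccc(CN(CCCCCCC(=O)O)S(C)(=O)=O)cc1`, gives 887 nM.
Compound 2, `CCCCC(O)c1ccc(CN(CCCCCCC(=O)O)S(C)(=O)=O)cc1`, gives 423 nM.
Compound 3, `CC(C)(C)c1ccc(CN(Cc2cccc(CCC(=O)O)c2)S(=O)(=O)c2ccccc2)cc1`, gives 0.2 nM.

Compound 3 gives the lowest number of the three; compound 2 comes nearest and compound 1 lies furthest off, both gaps well beyond the scatter. Among the compounds with values here, the one step within the set, a 2.1-fold lower number from compound 1 to compound 2 (0.32 log units; beyond the scatter), concerns the substituent on the aromatic carbon and leaves the sulfonyl untouched.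

Compound 4, `CC(C)(C)c1ccc(CN(Cc2cccc(CCC(=O)O)c2)S(C)(=O)=O)cc1`, is the next point on the series. The change from compound 3 is methyl in place of phenyl on a sulfonyl sulfur, phenylsulfonyl to methylsulfonyl. Within the data shown here, no measured pair isolates this change: compounds 1 and 2 carry a methylsulfonyl, but on a different core with a different acid chain, so their distance from compound 3 cannot be laid at the sulfonyl alone, and the step from compound 1 to compound 2 does not bear on it either. Among the measured compounds shown here, the only hint is that compound 3, the sole member with a phenylsulfonyl, gives 0.2 nM. A moderate rise in this assay is therefore expected for compound 4, with wide uncertainty. For compound 4 the estimate is 2 nM, range 0.3 nM to 20 nM. The expected step is a 10-fold higher number from compound 3 to compound 4 (1.00 log units; beyond the scatter).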

Compound 4, half-maximal effective concentration: 48 nM
Compound 4: middle estimate off by 24-fold (1.38 log units), on the low side; the whole stated range lies below it.
By their numbers in this assay, from the lowest: compound 3; then compound 4; then compound 2; then compound 1.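

In this assay, within the data shown here, compound 3 and compound 4 form the first measured pair that isolates the group on the sulfonyl sulfur, and methyl in place of phenyl gives a 240-fold higher number from compound 3 to compound 4 (2.38 log units; beyond the scatter). This position is therefore highly sensitive to the change on this core, and the step is much larger than the only earlier one, a 2.1-fold lower number from compound 1 to compound 2 (0.32 log units; beyond the scatter), which concerns a different position on a different core. Nothing at hand accounts for the size of the step.

On these data alone, whether an ethyl, a cyclohexyl or a pyridyl group on the sulfonyl sulfur would give a number nearer that of compound 3 or compound 4 remains open. Also open, as far as these compounds go, is whether a phenylsulfonyl in place of the methylsulfonyl would produce a step of similar size on the core and acid chain of compound 1.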